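This account rests on a few compounds, and the source may have more. Where it says the series, first, only, none or still open, it means among the compounds named here.

In a physicochemical assay for solubility, measured as kinetic solubility (a lower number here means a less soluble compound, a higher number a more soluble compound), compound 1 `O=C(NCc1ccc(Cl)cc1)c1ncc2cccnc2c1O` gives > 250000 nM, which is a limit of the assay and not a number. Compound 2 `Cc1n[nH]c(-c2ncc3c(-c4ccccc4C(F)(F)F)ccnc3c2O)n1` gives > 250000 nM, also a limit. Compound 3 `COc1ccccc1-c1nc(-c2nnc(C)o2)c(O)c2ncccc12` gives > 250000 nM, again a limit. Compound 1 therefore stands with the other two at the limit of > 250000 nM in this assay, at which 3 of the 3 values shown sit, and none of the three has an exact number. Compound 4 `COc1ccc(CNC(=O)c2ncc3cccnc3c2O)cc1` keeps the rest of compound 1 but has methoxy in place of chloro on an aromatic carbon. Going by the values given here, no measured pair shows the size of such a change, so no shift beyond the scatter is expected in this assay. The expected step, a number no higher from compound 1 to compound 4 (the limit leaves the size open), is therefore small. For compound 4, the estimated value is 250000 nM, with an expected range from 120000 nM to 250000 nM.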

Compound 4, solubility: > 250000 nM
Compound 4: only a limit was reported; the forecaster's own chance of this, stated with the estimate: 80%; the middle value sits exactly at the limit.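

No step can be read from compound 1 to compound 4, because both values are limits and not numbers: the limit of > 250000 nM in this assay, at which 4 of the 4 values shown sit.

The compounds shown leave open which structural change, if any, would bring a compound off that limit in this assay.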